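Cytotoxicity notes: from compound 1 to compound 4

The compounds below may be only part of what the source reports. "The series", "measured", "known", "first", "only" and "open" are said of these compounds alone.

Compound 1 `COC(=O)c1cc(-c2cccc(NC(=O)c3ccc(/C=C/C(=O)c4cccnc4)cc3)c2)on1` has no result in an ADME assay on Vero cells (Chlorocebus sabaeus) for cytotoxicity, read by MTT assay, with a stated time of 72 h; on this read-out lower numbers stand for higher toxicity in this test and higher numbers for lower toxicity in this test; its entry reads "not determined" (no result reported). Compound 2 `COC(=O)c1cc(-c2cccc(NC(=O)c3ccc(/C=C/C(=O)c4ccc(OC)cc4OC)cc3)c2)on1` in this assay gives a limit, > 50 ug/mL. Compound 3 `COC(=O)c1cc(-c2cccc(NC(=O)c3ccc(/C=C/C(=O)c4ccc(F)cc4F)cc3)c2)on1` in this assay gives a limit, > 40 ug/mL. For the measured compounds named here, the one measured step, 2,4-difluorophenyl in place of 2,4-dimethoxyphenyl on a carbonyl carbon, is a step that the two limits leave unreadable from compound 2 to compound 3; the limit of > 40 ug/mL in this assay, at which 1 of the 3 values shown sits, and the limit of > 50 ug/mL in this assay, at which 1 of the 3 values shown sits, are limits and not numbers. Compound 4 `COC(=O)c1cc(-c2cccc(NC(=O)c3ccc(/C=C/C(=O)c4ccccc4C)cc3)c2)on1` is reached from compound 1 by 2-methylphenyl in place of pyridin-3-yl on a carbonyl carbon. Going by the values given here, no measured step bears on this change, and compound 1 itself carries no number; the only guide is that both measured analogues stop at a limit, so no step beyond the scatter is expected. For compound 4 a reading at or near the limit is therefore expected, estimated at 50 ug/mL with a range of 20 ug/mL to 120 ug/mL.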

Compound 4, half-maximal cytotoxic concentration: > 25 ug/mL
Compound 4: a limit, no number; the forecaster's own chance of this, stated with the estimate: 70%; the middle value lies beyond the limit too.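

Compound 2, compound 3 and compound 4 all stop at limits and not numbers, so the steps from compound 2 and compound 3 to compound 4 cannot be read. Where each half-maximal cytotoxic concentration actually lies in this assay stays open.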